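The compounds below may be only part of what the source reports. "The series", "measured", "known", "first", "only" and "open" are said of these compounds alone.

Compound 1 `C[C@@]1(c2cc(NC(=O)c3ncc(C#N)cc3Cl)ccc2F)C=C(CF)OC(N)=N1`: 2.5
Compound 2 `Cc1cc(C#N)cnc1C(=O)Nc1ccc(F)c([C@]2(C)C=C(CF)OC(N)=N2)c1`: 2.5

In a physicochemical assay for lipophilicity, read by HPLC, in phosphate buffer, measured as octanol-water partition, with a stated time of 1 h, at pH 7.4 (a lower number here means a more polar compound, a higher number a more lipophilic compound), compound 2 stands at 2.5 and so level with compound 1 on these figures. Compound 3 `C[C@@]1(c2cc(NC(=O)c3cnc(C(F)F)cn3)ccc2F)C=C(CF)OC(N)=N1` carries 5-(difluoromethyl)pyrazin-2-yl in place of 5-cyano-3-methylpyridin-2-yl on a carbonyl carbon. Going by the values given here, one measured step bears on this only loosely: methyl in place of chloro on an aromatic carbon gave no change at the digits printed from compound 1 to compound 2 (within the scatter) and stayed within the scatter. No step beyond the scatter is expected, and the estimated step of a number 0.10 log units lower from compound 2 to compound 3 (within the scatter) leans slightly downward. For compound 3 the estimate is 2.4 with an expected range of 1.9 to 2.9 in this series.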

Compound 3, distribution coefficient: 2.5
For compound 3 the middle estimate is 0.10 log units below the measured one; the measured number falls inside the stated range.
By their numbers in this assay, from the lowest: compounds 1, 2 and 3 (each within the scatter of the next).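

In this assay, putting 5-(difluoromethyl)pyrazin-2-yl in place of 5-cyano-3-methylpyridin-2-yl on the carbonyl carbon gives no change at the digits printed from compound 2 to compound 3 (within the scatter), and putting it in place of 3-chloro-5-cyanopyridin-2-yl gives no change at the digits printed from compound 1 to compound 3 (within the scatter). The earlier step exchanged only one substituent, whereas here the whole aromatic ring and its nitrile are replaced with no step beyond the scatter. Nothing available explains this reading. Open: whether a group bearing an amine or a carboxylic acid at this place would stay level with compounds 1, 2 and 3. Any reading beyond these three compounds also remains open.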